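A few compounds are considered here, and "the series" means these few. Any claim that something is new, unique, unknown or untested is made for them only; others in the source may bear on it.

For the measured compounds named here, compound 1 `C=CC1=C(C(=O)NC2CCCCC2)C(c2ccc(OC)c(OC)c2)OC1` holds the only plain number in a functional assay on SW480 cells (Homo sapiens) for cytotoxicity, read by MTT assay, with a stated time of 24 h; a lower number here means a stronger inhibitor, a higher number a weaker inhibitor: compound 1 gives 19100 nM. Compound 2 `C=CC1=C(C(=O)NC2CCCCC2)C(c2ccc(OC)cc2)OC1` is reported there only as a limit, > 100000 nM, in this assay. Going by the values given here, the single measured step is an at least 5.2-fold higher number from compound 1 to compound 2 (0.71 log units; beyond the scatter), a change on the aromatic ring. Compound 3 `C=CC1=C(C(=O)NCc2ccc(C)cc2)C(c2ccc(OC)c(OC)c2)OC1` instead differs from compound 1 by 4-methylbenzyl in place of cyclohexyl on an amide-type nitrogen. Among the compounds with values here, no measured step touches the amide nitrogen, so the measured step gives no guide, and no shift beyond the scatter is expected in this assay. Compound 3 is therefore estimated at 20000 nM, within 5000 nM to 80000 nM, an expected step of a 1.0-fold higher number from compound 1 to compound 3 (0.02 log units; within the scatter).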

Compound 3, half-maximal inhibitory concentration: > 100000 nM
Compound 3 was reported as a limit; the forecaster's own chance of this, stated with the estimate: 25%; at least 5.0-fold (0.69 log units) between middle value and limit.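

For the compounds shown here, the amide nitrogen had no measured step before, and it now proves sensitive in this assay: 4-methylbenzyl in place of cyclohexyl on an amide-type nitrogen brings an at least 5.2-fold higher number from compound 1 to compound 3 (0.71 log units; beyond the scatter). Compound 3 gives only a limit, so this step has a minimum size and no exact one: the limit of > 100000 nM in this assay, at which 2 of the 3 values shown sit.

Still open, as far as these compounds go, is whether the ring, its methyl or the carbon linking it to the nitrogen drives the change. Unsubstituted benzyl, phenyl or cyclopentyl on this nitrogen would separate these, and could show whether any group here gives a lower number than cyclohexyl.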